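The source may report more compounds than this note shows. Statements on the series, on what has been measured and on what is new or still open speak of the compounds shown alone.

Compound 1, `O[C@@H]1[C@@H](O)[C@H](Oc2cccc3c(S)cccc23)OC[C@H]1O`, gives 110 uM in a functional assay on T-24 cells (Homo sapiens) for antiproliferative activity, read by crystal violet staining, with a stated time of 96 h; on this read-out lower numbers stand for an effect already at smaller amounts and higher numbers for an effect only at larger amounts of compound.
Compound 2, `O[C@@H]1[C@@H](O)[C@H](Oc2cccc3cccc(S)c23)OC[C@H]1O`, gives 45 uM in this assay.
Compound 3, `CCCSc1cccc2c(O[C@@H]3OC[C@@H](O)[C@H](O)[C@H]3O)cccc12`, gives 40 uM in this assay.

All three carry the same sugar joined through an oxygen to a two-ring aromatic core that also bears a sulfur. Compound 1 and compound 2 are built from the same atoms joined differently; the difference between the two cores is not broken down here. Compound 3 arises from compound 1 by a single change, (propyl in place of hydrogen on a sulfur), and in this assay this gave a 2.8-fold lower number from compound 1 to compound 3 (0.44 log units; beyond the scatter). The values of compound 2 and compound 3 lie within the scatter of each other, so no order can be read between them, whereas compound 2 stands beyond the scatter from compound 1.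

Compound 4, `CCCSc1cccc2cccc(O[C@@H]3OC[C@@H](O)[C@H](O)[C@H]3O)c12`, has not yet been measured. Going by the values given here, it arises from compound 2 by propyl in place of hydrogen on a sulfur, which is the same change as the one leading from compound 1 to compound 3, at the same place: on a sulfur whose other neighbour is an aromatic carbon. Among the compounds with values here, because the step of a 2.8-fold lower number from compound 1 to compound 3 (0.44 log units; beyond the scatter) was modest and is the only example of this change, the expected step in this assay is a 2.3-fold lower number from compound 2 to compound 4 (0.35 log units; beyond the scatter), with a generous width since the core differs. Compound 4 is thus estimated at 20 uM, with a likely range from 8 uM to 50 uM.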

Compound 4, concentration for half-maximal effect: 155 uM
Compound 4: middle estimate off by 7.8-fold (0.89 log units), on the low side; measured number above the stated range.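

In this assay, putting propyl in place of hydrogen on the sulfur gave a 3.4-fold higher number from compound 2 to compound 4 (0.54 log units; beyond the scatter), so the same change that lowered the number on the core of compound 1 raised it on the core of compound 2. Set side by side, the two steps run in opposite directions, and the gap between them is larger than repeated measurements would explain: the same change on two cores in this assay, a 2.8-fold lower number (0.44 log units; beyond the scatter) from compound 1 to compound 3 and a 3.4-fold higher number (0.54 log units; beyond the scatter) from compound 2 to compound 4, 9.5-fold (0.98 log units) apart, beyond the scatter of two such steps. Going by these compounds alone, this shows that, in this series, the result of the sulfanyl to propylsulfanyl change cannot simply be carried from one core to the other, even though the change itself is identical; it does not show why the two cores respond differently, and with only two pairs it cannot tell which response is the more typical or what a further core would do.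

The compounds shown leave open whether the opposite responses are specific to propyl or would also appear with a methyl, a longer chain such as hexyl, or a propyl chain ending in an amine or a carboxylic acid. They also leave open whether either core would give a steady trend across such a set of groups on the sulfur.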